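Replacing isopropylamino with 4-chlorophenyl on the shared core

The source may hold more compounds than are shown below. What is called first, only, known or untested is meant among the compounds shown, and "the series" means these compounds.

In a functional assay on MOLT-4 cells (Homo sapiens) (a lower number here means a stronger inhibitor, a higher number a weaker inhibitor), compound 3 `CC(C)Nc1ncnc2c1ncn2C[C@@H]1C[C@H](CO)c2ccccc21` gives 24 ug/mL. Compound 2 `OC[C@H]1C[C@@H](Cn2cnc3c(O)ncnc32)c2ccccc21` gives 24 ug/mL, and the exchange of hydroxy for isopropylamino shows no change at the digits printed from compound 2 to compound 3 (within the scatter). Compound 1 `Cc1ccc(-c2ncnc3c2ncn3C[C@@H]2C[C@H](CO)c3ccccc32)cc1` gives 1.4 ug/mL. Compound 3 therefore stands level with compound 2 at the weak end of the three numbers.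

Compound 4 `OC[C@H]1C[C@@H](Cn2cnc3c(-c4ccc(Cl)cc4)ncnc32)c2ccccc21` has 4-chlorophenyl in place of isopropylamino on an aromatic carbon.

The most relevant evidence is the step between the 4-methylphenyl and isopropylamino groups, a 17-fold higher number from compound 1 to compound 3 (1.23 log units; beyond the scatter). Read in reverse, it suggests that an aryl group at this carbon gives a much lower number. The hydroxy step, a 17-fold higher number from compound 1 to compound 2 (1.23 log units; beyond the scatter), is of the same size and points the same way. As far as these compounds go, no chlorine-bearing aryl group has been measured, so the transfer from 4-methylphenyl to 4-chlorophenyl remains untested. A large move to a lower number is expected, close in size to the step seen with compound 1. The expected step is a 12-fold lower number from compound 3 to compound 4 (1.08 log units; beyond the scatter). Compound 4 is estimated at 2 ug/mL, with an expected range of 0.7 ug/mL to 6 ug/mL.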

Compound 4, half-maximal inhibitory concentration: 0.63 ug/mL
Compound 4: the middle estimate sits 3.2-fold (0.50 log units) above what was measured; measured number below the stated range.
By their numbers in this assay, from the lowest: compound 4; then compound 1; then compounds 2 and 3 (each within the scatter of the next).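

In this assay a second aryl group on this aromatic carbon repeats the drop seen with 4-methylphenyl, giving a 38-fold lower number from compound 3 to compound 4 (1.58 log units; beyond the scatter) and a 38-fold lower number from compound 2 to compound 4 (1.58 log units; beyond the scatter) so the low numbers no longer rest on compound 1 alone. The group on the aryl ring also counts: chloro in place of methyl gives a 2.2-fold lower number from compound 1 to compound 4 (0.35 log units; beyond the scatter) and this modest step lies beyond the scatter, so the position still responds once an aryl group is in place. No measurement on hand explains either step.

Open, as far as these compounds go, is whether the drop needs a group on the aryl ring at all, as plain phenyl would show, and whether methoxy or trifluoromethyl in place of the chlorine lowers the number further. Also open, from the compounds shown here alone, is whether the ring must be aromatic, a question that cyclohexyl on the same carbon would address.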